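Amide nitrogen substituent: propyl to phenyl, first notes

This account rests on a few compounds, and the source may have more. Where it says the series, first, only, none or still open, it means among the compounds named here.

Measured so far:
compound 1, `C=CC1=C(C(=O)NCCC)C(c2ccc(F)cc2)OC1`: > 100000 nM
compound 2, `C=CC1=C(C(=O)NC(C)(C)C)C(c2ccc(OC)cc2)OC1`: > 100000 nM
to be measured: compound 3, `C=CC1=C(C(=O)Nc2ccccc2)C(c2ccc(F)cc2)OC1`

In a functional assay on QGY7701 cells (Homo sapiens) for cytotoxicity, read by MTT assay, with a stated time of 24 h (a higher number here means a weaker inhibitor, a lower number a stronger inhibitor), compound 1 gives > 100000 nM, which is a limit of the assay and not a number. Compound 2 gives > 100000 nM in this assay, again a limit rather than a number. For the measured compounds named here, both values therefore sit at the limit of > 100000 nM in this assay, at which 2 of the 2 values shown sit, so compound 1 stands nowhere in particular within the set: it is not placed above or below compound 2, and no step between measured compounds can be drawn. Compound 1 and compound 2 also differ in more than one place, so nothing is said here of what separates them.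

The step under consideration is from compound 1 to compound 3: phenyl in place of propyl on an amide-type nitrogen. Going by the values given here, with no measured step in this assay to lean on, and with both known values at the limit, the expected step from compound 1 to compound 3 in this assay is a number no higher from compound 1 to compound 3 (the limit leaves the size open), that is, none beyond the scatter, and a further limit is the most likely outcome. Compound 3 is accordingly estimated at 100000 nM, with a range from 20000 nM to 300000 nM.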

Compound 3, half-maximal inhibitory concentration: 46700 nM
The estimate for compound 3 lay 2.1-fold (0.33 log units) above the measured number; the measured number falls inside the stated range.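

In this assay, phenyl in place of propyl on an amide-type nitrogen gives an at least 2.1-fold lower number from compound 1 to compound 3 (0.33 log units; beyond the scatter), which shows that the read-out can move off the limit through a change at this nitrogen alone, with the rest of the core of compound 1 unchanged. Compound 1 gives > 100000 nM, a limit of the assay and not a number, so the step has a floor but no known size. Neither propyl nor phenyl carries a hydrogen-bond donor or acceptor, so the groups differ here in the aromatic ring and in heavy-atom count, and this single step does not tell those two apart.

A cyclohexyl or benzyl group, or a longer chain such as hexyl, on the same nitrogen would be needed to separate the ring from the carbon count, and the compounds shown do not say whether the aromatic ring itself matters. Only one number is available so far, so no trend along the series can be read, and the remaining values give no ranking: the limit of > 100000 nM in this assay, at which 2 of the 3 values shown sit.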